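Replacing 2-fluorophenyl with (pyridin-2-yl)methyl in compound 3

The source may hold more compounds than are shown below. What is called first, only, known or untested is meant among the compounds shown, and "the series" means these compounds.

Measured in a functional assay on a cell-free system (plasma, Homo sapiens), with a stated time of 3 min; a higher number here means a weaker inhibitor, a lower number a stronger inhibitor:
- compound 1 `CC(C)(C)C[C@@H](O)C(=O)N1[C@H](C(=O)NCc2cc(Cl)ccc2-n2cnnn2)C[C@@H]2C[C@@H]21`: 570 nM
- compound 2 `O=C(NCc1cc(Cl)ccc1-n1cnnn1)[C@@H]1C[C@@H]2C[C@@H]2N1C(=O)[C@H](O)c1ccccc1F`: 770 nM

Compound 2 stands at 770 nM. Compound 1 stands at 570 nM, and the two values lie within the scatter of each other in this assay, so neither can be ranked on these numbers.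

The next compound, compound 3 `O=C(NCc1cc(Cl)ccc1-n1cnnn1)[C@@H]1C[C@@H]2C[C@@H]2N1C(=O)[C@H](O)Cc1ccccn1`, keeps the core of compound 2 and differs in one group: (pyridin-2-yl)methyl in place of 2-fluorophenyl on a saturated chain carbon bound to a carbonyl carbon and an oxygen on a saturated carbon. In words, (pyridin-2-yl)methyl takes the place of 2-fluorophenyl on a saturated chain carbon bound to a carbonyl carbon and an oxygen on a saturated carbon.

Among the measured compounds shown here, only one measured step bears on this change: a 1.4-fold higher number from compound 1 to compound 2 (0.13 log units; within the scatter). It replaced neopentyl with 2-fluorophenyl at that same place and stayed within the scatter. For the measured compounds named here, no measured compound carries the (pyridin-2-yl)methyl group, so the evidence is thin and the direction of any change remains open. The expected step is therefore none beyond the scatter, and the estimate is a 1.0-fold lower number from compound 2 to compound 3 (0.01 log units; within the scatter). For compound 3 the estimated value is 750 nM, with an expected range from 250 nM to 2300 nM.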

Compound 3, half-maximal inhibitory concentration: 1000 nM
Estimate against measurement, compound 3: 1.3-fold (0.12 log units) below; the measured number falls inside the stated range.
By their numbers in this assay, from the lowest: compounds 1, 2 and 3 (each within the scatter of the next).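

In this assay, the exchange of a carbon-only aromatic ring for one with a hetero atom and a hydrogen-bond acceptor, at the place on a saturated chain carbon bound to a carbonyl carbon and an oxygen on a saturated carbon, gives a 1.3-fold higher number from compound 2 to compound 3 (0.11 log units; within the scatter) and so does not separate the two groups. The wider comparison, a 1.8-fold higher number from compound 1 to compound 3 (0.24 log units; within the scatter), also stays within the scatter, so all three pairs among neopentyl, 2-fluorophenyl and (pyridin-2-yl)methyl remain unresolved here, and three quite different groups on the shared core cannot be ranked on these numbers. Nothing available gives a measured reason for this flat outcome, and with steps this small there is no difference to explain.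

Still open, as far as these compounds go, is whether any group at this place would move the number beyond the scatter, for example a primary amine, a carboxylic acid or a longer alkyl chain. Compound 3 also differs from compound 2 in both the ring and the added methylene, so a plain benzyl group would be needed to tell the ring nitrogen apart from the extra carbon.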